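Replacing butylamino with (ethylamino)methyl on a carbonyl carbon

The source may hold more compounds than are shown below. What is called first, only, known or untested is meant among the compounds shown, and "the series" means these compounds.

In a functional assay on the whole organism for inhibition, with Mus musculus as the target (a lower number here means that less compound is needed, a higher number that more compound is needed for the effect), compound 1 (`CCCCNC(=O)Nc1cccc2c1CN(C)CC2c1ccc(Cl)cc1`) gives 44 mg/kg. Compound 2 (`CCCCNC(=O)Nc1cccc2c1CN(C)CC2c1ccc(C)cc1`) gives 40 mg/kg, so the two numbers lie within the scatter of each other and compound 1 stands level with compound 2. Going by the values given here, the only measured step, a 1.1-fold lower number from compound 1 to compound 2 (0.04 log units; within the scatter), swaps chloro for methyl on an aromatic carbon. That is a different place from the one changing now, so it offers only weak guidance. Compound 3 (`CCNCC(=O)Nc1cccc2c1CN(C)CC2c1ccc(Cl)cc1`) has (ethylamino)methyl in place of butylamino on a carbonyl carbon. Among the compounds with values here, no measured compound shows what a change at this place does, so the data favour no direction, and the uncertainty is wide. The expected step is a 1.1-fold lower number from compound 1 to compound 3 (0.04 log units; within the scatter), which means no change beyond the scatter is anticipated. Compound 3 is estimated at 40 mg/kg, with an expected range from 15 mg/kg to 120 mg/kg.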

Compound 3, dose for half-maximal effect: 24 mg/kg
Compound 3: the middle estimate sits 1.7-fold (0.22 log units) above what was measured; low and high end bracket the measured number.
By their numbers in this assay, from the lowest: compounds 3, 2 and 1 (each within the scatter of the next).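

In this assay, the exchange at this carbonyl carbon gives a 1.8-fold lower number from compound 1 to compound 3 (0.26 log units; within the scatter), so this place accepts (ethylamino)methyl in place of butylamino with no shift beyond the scatter. The entering group carries a hydrogen-bond acceptor that butylamino lacks, yet compound 3 stays level with compound 1. No measurement shown here explains this result.

The step alters the chain and the way it is attached to the carbonyl carbon at once, so the compounds shown cannot separate these two parts of the change. Also open, as far as these compounds go, is whether a larger group on the same methyl, such as butylamino, dimethylamino or a piperidine ring, would move the number beyond the scatter.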